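A Chloro Substituent Moves to the Five-Membered Ring

The compounds below may be only part of what the source reports. "The series", "measured", "known", "first", "only" and "open" are said of these compounds alone.

Of the compounds shown here, three have been tested in a functional assay on KB cells (Homo sapiens) for antiproliferative activity, read by colorimetric assay and MTT assay; on this read-out lower numbers stand for stronger inhibition and higher numbers for weaker inhibition. Compound 1 `O=S(=O)(Nc1cccc2cc[nH]c12)c1ccc(Cl)cc1` gives 6 ug/mL. Compound 2 `O=S(=O)(Nc1cc(Cl)cc2cc[nH]c12)c1ccc(Cl)cc1` carries an added chloro and in this assay gives 9.1 ug/mL. The change from compound 1 to compound 2 is chloro in place of hydrogen on an aromatic carbon and it produced a 1.5-fold higher number from compound 1 to compound 2 (0.18 log units; within the scatter). Compound 3 `N#Cc1ccc(S(=O)(=O)Nc2ccc(Cl)c3cc[nH]c23)cc1` carries a nitrile and a chlorine; in this assay compound 3 gives 15 ug/mL, a higher number than compound 1 and a number that sits within the scatter of compound 2. The difference between the core of compound 3 and the core of compound 1 is not broken down here.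

Compound 4 `N#Cc1ccc(S(=O)(=O)Nc2ccc(Cl)c3c(Cl)c[nH]c23)cc1` has not yet been measured. Among the measured compounds shown here, it differs from compound 3 by chloro in place of hydrogen on an aromatic carbon This is the same kind of change as the one from compound 1 to compound 2, but not the same: there the chloro entered a six-membered aromatic ring of carbon only, meta to a fused ring, meta to a large group and para to a fused ring, whereas here it enters a five-membered aromatic ring with one nitrogen, two ring bonds from the ring nitrogen. With a single earlier example of this kind of change, on a different ring, the expectation rests lightly: a step close to the earlier one is expected, a 1.3-fold higher number from compound 3 to compound 4 (0.12 log units; within the scatter), because the earlier change gave a 1.5-fold higher number from compound 1 to compound 2 (0.18 log units; within the scatter). Compound 4 is thus estimated to give 20 ug/mL in this assay, most likely between 10 ug/mL and 40 ug/mL.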

Compound 4, half-maximal inhibitory concentration: 13 ug/mL
Beside the measured number, compound 4's estimate is 1.5-fold (0.19 log units) above it; the range from low to high includes it.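

In this assay, putting a chloro in place of hydrogen on the five-membered ring gives a 1.2-fold lower number from compound 3 to compound 4 (0.06 log units; within the scatter), so this single step cannot be told apart from the ordinary spread of repeated measurements. Set beside the earlier step on a six-membered ring, the new step shows that the same swap stayed small on both cores, and the two steps agree as closely as this kind of measurement can tell: the same change on two cores in this assay, a 1.5-fold higher number (0.18 log units; within the scatter) from compound 1 to compound 2 and a 1.2-fold lower number (0.06 log units; within the scatter) from compound 3 to compound 4, 1.8-fold (0.24 log units) apart, within the scatter of two such steps. Among the compounds shown here, this supports carrying the change from one core to another as a small step, but it rests on only two pairs, with the chloro on a different ring in each, and it does not show that the swap never matters or settle whether the number truly goes up or down.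

The compounds shown leave open whether a group other than chloro on that same carbon of the five-membered ring, such as an amine, a carboxylic acid or a longer chain, would move the number beyond the scatter. They also leave open whether a chloro at this place on the core of compound 1 would give a similarly small step.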